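Swapping the amide aryl group on a naphthalene-linked thiazolidinedione

A few compounds are considered here, and "the series" means these few. Any claim that something is new, unique, unknown or untested is made for them only; others in the source may bear on it.

Of the compounds shown here, three have been measured so far in an assay on isolated protein for inhibition of histone deacetylase 4 (Homo sapiens), with a stated time of 1 h; on this read-out lower numbers stand for stronger inhibition and higher numbers for weaker inhibition. Compound 1 `O=C(CN1C(=O)S/C(=C/c2ccccn2)C1=O)Nc1nc2ccccc2s1` gives 9300 nM. Compound 2 `O=C(COc1ccc2cc(/C=C3/SC(=O)NC3=O)ccc2c1)Nc1cc(Cl)cc(C(F)(F)F)c1` gives 4000 nM, and compound 3 `Cc1cc(NC(=O)COc2ccc3cc(/C=C4/SC(=O)NC4=O)ccc3c2)no1` gives 1700 nM. Compound 2 thus stands second highest of the three numbers, between compound 1 and compound 3.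

Compound 4 `Cc1cccc2sc(NC(=O)COc3ccc4cc(/C=C5/SC(=O)NC5=O)ccc4c3)nc12` is not yet measured. Relative to compound 2, the change is 4-methyl-1,3-benzothiazol-2-yl in place of 3-chloro-5-(trifluoromethyl)phenyl on an amide-type nitrogen.

For the measured compounds named here, one measured step bears on this: the step of a 2.4-fold lower number from compound 2 to compound 3 (0.37 log units; beyond the scatter), also a swap of the group on the same amide-type nitrogen, where a 1,2-oxazole replaced the halogenated phenyl ring. Going by the values given here, compound 1 carries a 1,3-benzothiazol-2-yl on its amide nitrogen but has a different core, and its number is higher than that of compound 2; no direct step links them, so it gives only a loose hint.

On balance, a modest step towards a lower number is expected, a 1.4-fold lower number from compound 2 to compound 4 (0.15 log units; within the scatter), though it may fall within the scatter. Compound 4 is estimated at 2800 nM, with a range from 900 nM to 9000 nM.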

Compound 4, half-maximal inhibitory concentration: 1200 nM
Beside the measured number, compound 4's estimate is 2.3-fold (0.37 log units) above it; measured number inside the range.
By their numbers in this assay, from the lowest: compounds 4 and 3 (each within the scatter of the next); then compound 2; then compound 1.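

In this assay, a second, very different group on the amide-type nitrogen also beats the 3-chloro-5-(trifluoromethyl)phenyl of compound 2: 4-methyl-1,3-benzothiazol-2-yl gives a 3.3-fold lower number from compound 2 to compound 4 (0.52 log units; beyond the scatter), so the gain is not limited to the 5-methyl-1,2-oxazol-3-yl of compound 3. The two replacements cannot be told apart, with a 1.4-fold lower number from compound 3 to compound 4 (0.15 log units; within the scatter), even though one carries two rings and the other is the smaller group on compound 3. No measurement shown explains why either replacement gives a lower number than the halogenated phenyl ring.

As far as these compounds go, whether the methyl on the benzothiazole matters remains open, as a benzothiazole without it appears only on the different core of compound 1. Also open, from the compounds shown here alone, is how a plain phenyl ring without chlorine or trifluoromethyl, or a ring carrying a carboxylic acid, would read at this nitrogen.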